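This account rests on a few compounds, and the source may have more. Where it says the series, first, only, none or still open, it means among the compounds named here.

Working notes on the series.

Compound 1 `CC(=O)OC[C@H]1O[C@@H](n2cc(-c3cc(-c4ccc(C(C)(C)C)cc4)no3)c(=O)[nH]c2=O)C[C@@H]1OC(C)=O` was tested in a functional assay on NCI-H23 cells (Homo sapiens) for cytotoxicity, read by sulforhodamine B assay, tested at 10 uM (on this read-out lower numbers stand for less inhibition and higher numbers for more inhibition at the one concentration tested (going by the name of the read-out)), and gives 112%. Two further compounds were run in the same test: compound 2 `CC(=O)OC[C@H]1O[C@@H](n2cc(-c3cn(Cc4ccc(C(C)(C)C)cc4)nn3)c(=O)[nH]c2=O)C[C@@H]1OC(C)=O` gives 106%, and compound 3 `CCCCCCCCc1cc(-c2cn([C@H]3C[C@H](O)[C@@H](CO)O3)c(=O)[nH]c2=O)on1` gives 120%. Within the data shown here, all three numbers are high at the single concentration used, and compound 1 lies within the usual scatter of both compound 2 and compound 3, so the three cannot be told apart on these readings; no step between them is beyond the scatter.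

Compound 4 `CCCCc1ccc(-c2cc(-c3cn([C@H]4C[C@H](OC(C)=O)[C@@H](COC(C)=O)O4)c(=O)[nH]c3=O)on2)cc1` has not yet been measured in this assay. Against compound 1 the change is butyl in place of tert-butyl on an aromatic carbon, the two compounds holding the same atoms joined differently. Among the measured compounds shown here, the measured set gives no step of its own to lean on, so the expectation rests on the observation that every compound so far gives a high number on this read-out. The step from compound 1 is therefore expected to be a number 2 percentage points lower from compound 1 to compound 4 (within the scatter), that is, none beyond the scatter in either direction. For compound 4 the estimate in this assay is 110%, with a range from 95% to 125%.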

Compound 4, a percentage reported as inhibition, at one concentration (the size of the read-out at that concentration, not a potency): 97.4%
Compound 4: the middle estimate sits 12.6 percentage points above what was measured, within the range that was stated.
By their numbers in this assay, from the lowest: compounds 4, 2, 1 and 3 (each within the scatter of the next, the first and the last beyond it).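

In this assay, among these compounds, the change from 4-(tert-butyl)phenyl to 4-butylphenyl gives a number 14.6 percentage points lower from compound 1 to compound 4 (beyond the scatter), the first step that can be read at a single place. It is modest but beyond the scatter, so the group on this aromatic carbon, para to a large group, is not indifferent on this read-out: two groups with the same atoms, joined differently, do not read alike, and the tert-butyl compound holds the higher number of this one pair. No measurement at hand accounts for the step, which stands as an observation on these two compounds alone.

On these data alone, it remains open how a longer chain such as hexyl, or a primary amine or a carboxylic acid at the end of the butyl chain, would read at this place, and whether the step between tert-butyl and butyl would recur on a compound with the shared core changed. As far as these compounds go, since each reading comes from one concentration, it also remains open whether the step would carry over to a measure of potency.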